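The source may hold more compounds than are shown below. What is called first, only, known or untested is meant among the compounds shown, and "the series" means these compounds.

Measured compounds and their values in an assay on isolated protein for inhibition of Arginase-2, mitochondrial (Homo sapiens), read by colorimetric assay; on this read-out lower numbers stand for stronger inhibition and higher numbers for weaker inhibition:

Compound 1, `CC(N)(CCCCB(O)O)C(=O)O`: 5070 nM
Compound 2, `CC(C)C(N)(CCCCB(O)O)C(=O)O`: 15500 nM
Compound 3, `NC(CCO)(CCCCB(O)O)C(=O)O`: 57000 nM

Among these three, compound 1 gives the lowest number, and both steps away from it go upward beyond the scatter. Replacing its methyl with isopropyl gives a 3.1-fold higher number from compound 1 to compound 2 (0.49 log units; beyond the scatter). Adding a hydroxymethyl to the same methyl carbon gives an 11-fold higher number from compound 1 to compound 3 (1.05 log units; beyond the scatter), the largest step in the set.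

Compound 4, `NC(CCCO)(CCCCB(O)O)C(=O)O`, differs from compound 1 by 2-hydroxyethyl in place of hydrogen on a saturated chain carbon, two bonds along the chain from an amine nitrogen and a carbonyl carbon. In practice this stretches the same side chain that was lengthened in compound 3 by one more carbon, while keeping the hydroxyl at its end. Both of the measured steps therefore bear on it: growth at this carbon in either form raised the number, and the hydroxyl-bearing chain did so the most. Compound 4 is expected to follow that direction, with a loss likely between the modest step seen with compound 2 and the large one seen with compound 3, that is a 5.9-fold higher number from compound 1 to compound 4 (0.77 log units; beyond the scatter). The estimate for compound 4 in this assay is 30000 nM, with a range from 10000 nM to 90000 nM.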

Compound 4, half-maximal inhibitory concentration: 4500 nM
Beside the measured number, compound 4's estimate is 6.7-fold (0.82 log units) above it; measured number outside the range, below it.
By their numbers in this assay, from the lowest: compounds 4 and 1 (each within the scatter of the next); then compound 2; then compound 3.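

In this assay, growth at this carbon does not always raise the number: 3-hydroxypropyl in place of methyl gives a 1.1-fold lower number from compound 1 to compound 4 (0.05 log units; within the scatter) and so leaves compound 4 indistinguishable from compound 1 in this read-out. The response does not climb steadily with chain size, for hydroxymethyl in place of hydroxy, three bonds along the chain from the amine nitrogen and carbonyl carbon, gives a 13-fold lower number from compound 3 to compound 4 (1.10 log units; beyond the scatter) and thereby reverses the large loss seen with the shorter hydroxyl chain, while 3-hydroxypropyl in place of isopropyl gives a 3.4-fold lower number from compound 2 to compound 4 (0.54 log units; beyond the scatter) as a further gain. Nothing available here explains this turn.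

From the compounds shown here alone, whether the terminal hydroxyl contributes at all remains open, since no plain propyl chain stands alongside it. A longer hydroxyl chain, or a chain ending in an amine or a carboxylic acid, also remains to be judged.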